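From Isopropyl to Cyclohexyl: What to Expect for Compound 4

The compounds below may be only part of what the source reports. "The series", "measured", "known", "first", "only" and "open" are said of these compounds alone.

The measured compounds:
compound 1 `COC(=O)C#CC(O/C=C/C(=O)OC)C(C)c1ccccc1`: 1200 nM
compound 2 `COC(=O)C#CC(CC(C)C)O/C=C/C(=O)OC`: 380 nM
compound 3 `COC(=O)C#CC(O/C=C/C(=O)OC)C(C)C`: 750 nM

All three were tested in a functional assay on SW1573 cells (Homo sapiens) for antiproliferative activity, read by sulforhodamine B assay, with a stated time of 48 h; a lower number here means a stronger inhibitor of growth, a higher number a weaker inhibitor of growth. Among these three numbers compound 3 has the second highest. Its nearest neighbour is compound 1, and the change a 1.6-fold lower number from compound 1 to compound 3 (0.20 log units; within the scatter) stays within the scatter. Its furthest neighbour is compound 2, and the change a 2.0-fold higher number from compound 2 to compound 3 (0.30 log units; within the scatter) also stays within the scatter, so none of the three can be called stronger or weaker than another.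

Compound 4 `COC(=O)C#CC(O/C=C/C(=O)OC)C1CCCCC1` differs from compound 3 in one place: cyclohexyl in place of isopropyl on a saturated chain carbon bound to an oxygen on an unsaturated carbon and a triple-bonded carbon. For the measured compounds named here, the only measured step at this same place is the one from compound 2 to compound 3, where isobutyl became isopropyl, and it was a 2.0-fold higher number from compound 2 to compound 3 (0.30 log units; within the scatter), within the scatter. The step from compound 1 to compound 3 concerns a different place and was likewise within the scatter. Nothing measured here, then, points to a change beyond the scatter in this assay when cyclohexyl enters.

Compound 4 is therefore estimated at 600 nM, with a likely range from 250 nM to 1500 nM. The expected step is a 1.3-fold lower number from compound 3 to compound 4 (0.10 log units; within the scatter), and it is expected to lie within the scatter.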

Compound 4, concentration for 50% growth inhibition: 2100 nM
Compound 4: the middle estimate sits 3.5-fold (0.54 log units) below what was measured; the measured number lies above the stated range.
By their numbers in this assay, from the lowest: compounds 2, 3, 1 and 4 (each within the scatter of the next, the first and the last beyond it).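

At the saturated chain carbon bound to an oxygen on an unsaturated carbon and a triple-bonded carbon, replacing isopropyl with cyclohexyl gives a 2.8-fold higher number from compound 3 to compound 4 (0.45 log units; beyond the scatter) in this assay and so moves the growth-inhibition number by more than the usual scatter, which the earlier step at this place did not do. The replacement of isobutyl with cyclohexyl at the same place gives a 5.5-fold higher number from compound 2 to compound 4 (0.74 log units; beyond the scatter) and also passes beyond the scatter, showing that the number here does depend on the group attached, with cyclohexyl on the weaker side of both isopropyl and isobutyl. No supporting measurement explains why cyclohexyl, with its six carbons and its ring, behaves this way.

The compounds shown cannot tell whether the ring or the number of carbons matters more, since cyclohexyl brings both at once; a straight hexyl chain and a cyclopentyl ring at this place would help to pull the two apart. Going by these compounds, whether a cyclohexyl ring carrying an amine or a carboxylic acid would follow the same trend also remains open.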